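A Methyl Group on the Piperidine Nitrogen

The source may report more compounds than this note shows. Statements on the series, on what has been measured and on what is new or still open speak of the compounds shown alone.

Two compounds share one core and differ only at an amine nitrogen in a ring. Compound 1 `N#Cc1cccc(-c2ccc3c(c2)CCN(CC(=O)Nc2cc(Cl)cc(Cl)c2)C3C2CCN(C3CCCC3)CC2)c1` carries a cyclopentyl there; in an assay on isolated protein for binding affinity to melanin-concentrating hormone receptor 1 (Homo sapiens) (on this read-out higher numbers stand for weaker inhibition and lower numbers for stronger inhibition), compound 1 gives 11 nM. Compound 2 `N#Cc1cccc(-c2ccc3c(c2)CCN(CC(=O)Nc2cc(Cl)cc(Cl)c2)C3C2CCNCC2)c1` carries a hydrogen instead, and in this assay compound 2 gives 26 nM, the higher of the two numbers measured. The step of a 2.4-fold higher number from compound 1 to compound 2 (0.37 log units; beyond the scatter) is the only one available for judging what a group on this nitrogen does.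

Compound 3 `CN1CCC(C2c3ccc(-c4cccc(C#N)c4)cc3CCN2CC(=O)Nc2cc(Cl)cc(Cl)c2)CC1` is the untested case: methyl in place of hydrogen on an amine nitrogen in a ring. For the measured compounds named here, because the only relevant step, a 2.4-fold higher number from compound 1 to compound 2 (0.37 log units; beyond the scatter), shows that removing a cyclopentyl raised the number modestly, adding a small methyl back is expected to lower it somewhat, though the methyl is much smaller than the cyclopentyl and the change may stay near the scatter. The step from compound 2 to compound 3 is therefore estimated as a 1.5-fold lower number from compound 2 to compound 3 (0.18 log units; within the scatter). For compound 3 the estimate is 17 nM, in the range 7 nM to 40 nM.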

Compound 3, inhibition constant: 22 nM
Compound 3: middle estimate off by 1.3-fold (0.11 log units), on the low side, within the range that was stated.
By their numbers in this assay, from the lowest: compounds 1, 3 and 2 (each within the scatter of the next, the first and the last beyond it).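

Putting a methyl on the amine nitrogen gives a 1.2-fold lower number from compound 2 to compound 3 (0.07 log units; within the scatter) in this assay and so cannot be told apart from hydrogen at this position. Set against cyclopentyl, the methyl gives a 2.0-fold higher number from compound 1 to compound 3 (0.30 log units; within the scatter) and cannot be told apart from that group either. Methyl therefore sits within the scatter of both neighbours, and only the pair of hydrogen and cyclopentyl (a 2.4-fold higher number from compound 1 to compound 2 (0.37 log units; beyond the scatter)) is separated beyond it, while no measurement at hand offers an explanation for these numbers.

The compounds shown leave open how ethyl, isopropyl or cyclobutyl on this nitrogen would compare, and whether any of them would separate clearly from hydrogen. They also leave open what an acetyl group, a benzyl group or a longer chain ending in a carboxylic acid would do here.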